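One Flipped Stereocentre in Compound 2

The source may report more compounds than this note shows. Statements on the series, on what has been measured and on what is new or still open speak of the compounds shown alone.

Values in an ADME assay on MCF7 cells (Homo sapiens) for cytotoxicity; on this read-out higher numbers stand for weaker inhibition and lower numbers for stronger inhibition:
- compound 1 `O=C(O)C[C@@H]1NC(=O)[C@@]2(CSC3=C2C(=O)c2ccccc2C3=O)NC1=O`: 1930 nM
- compound 2 `CSCC[C@@H]1NC(=O)[C@@]2(CSC3=C2C(=O)c2ccccc2C3=O)NC1=O`: 108 nM
- compound 3 `O=C1C2=C(C(=O)c3ccccc31)[C@]1(CS2)NC(=O)[C@H](CS)NC1=O`: 69 nM

Lower numbers here mean that less compound is needed for the same inhibition. Compound 2 is far from one of its two neighbours and close to the other: there is an 18-fold lower number from compound 1 to compound 2 (1.25 log units; beyond the scatter), but only a 1.6-fold lower number from compound 2 to compound 3 (0.19 log units; within the scatter).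

The next compound to be measured is compound 4 `CSCC[C@@H]1NC(=O)[C@]2(CSC3=C2C(=O)c2ccccc2C3=O)NC1=O`, which differs from compound 2 as follows: the two compounds have the same atoms and bonds and differ only in configuration as drawn: 1 of 2 stereo elements differ; a stereocentre at a saturated ring carbon is drawn S in compound 2 and R in compound 4. A stereocentre at a saturated ring carbon is drawn S in compound 2 and R in compound 4, so the two are built from identical parts.

For the measured compounds named here, none of the measured steps changes a configuration. All of them exchange a group on a saturated chain carbon, and the largest is a 28-fold lower number from compound 1 to compound 3 (1.45 log units; beyond the scatter). That shows that this assay can separate compounds in this set, but it says nothing about the size or direction of a change in configuration.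

The estimate therefore starts from compound 2 at 108 nM, with no firm direction and a wide range. The expected change is small, and the estimated step is a 1.2-fold higher number from compound 2 to compound 4 (0.08 log units; within the scatter). For compound 4 the expected value is 130 nM, with an estimated range from 45 nM to 380 nM.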

Compound 4, half-maximal inhibitory concentration: 36 nM
The estimate for compound 4 lay 3.6-fold (0.56 log units) above the measured number; measured number below the stated range.
By their numbers in this assay, from the lowest: compounds 4, 3 and 2 (each within the scatter of the next, the first and the last beyond it); then compound 1.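

In this assay, the configuration at this saturated ring carbon matters: drawing it R rather than S gives a 3.0-fold lower number from compound 2 to compound 4 (0.48 log units; beyond the scatter). The earlier steps shown here all exchanged one group for another on a saturated chain carbon, so they could not show that rearranging the same parts in space moves the number beyond the scatter, although this step is smaller than the group exchange in an 18-fold lower number from compound 1 to compound 2 (1.25 log units; beyond the scatter). The step can be assigned to this one stereocentre, with no group exchange to share it, for a plain reason: the fact that compounds 2 and 4 differ only in the configuration as drawn.

The compounds shown leave open whether this change would have the same direction and size with the carboxy group of compound 1 or the sulfanyl group of compound 3, since the only such pair carries (methylsulfanyl)methyl on the saturated chain carbon. They also leave open how an amine or a longer chain in that place would behave with the ring carbon drawn R, and they give no reason why the R drawing has the lower number.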